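From 3-methoxyphenyl to 2-ethoxyphenyl on the amine nitrogen

A few compounds are considered here, and "the series" means these few. Any claim that something is new, unique, unknown or untested is made for them only; others in the source may bear on it.

Compound 1 `O=C1C(Nc2ccc(C(F)(F)F)cc2)=CC(=O)c2c1nc1n2[C@H]2OC[C@@H](O)[C@H]2OC1` gives 2250 nM
Compound 2 `CCOc1ccc(NC2=CC(=O)c3c(nc4n3[C@H]3OC[C@@H](O)[C@H]3OC4)C2=O)cc1` gives > 4000 nM as a limit of the assay
Compound 3 `COc1cccc(NC2=CC(=O)c3c(nc4n3[C@H]3OC[C@@H](O)[C@H]3OC4)C2=O)c1` gives 3340 nM

In a functional assay on ECa-109 cells for inhibition, with ECa-109 cell line (Homo sapiens) as the target, read by sulforhodamine B assay (a higher number here means a weaker inhibitor, a lower number a stronger inhibitor), compound 3 gives 3340 nM and compound 1 gives 2250 nM as exact numbers. The step joining them is a 1.5-fold higher number from compound 1 to compound 3 (0.17 log units; within the scatter) and so the ordinary spread between repeat measurements is enough to cover it. Compound 2 has only a limit (> 4000 nM).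

Going by the values given here, compound 4 `CCOc1ccccc1NC1=CC(=O)c2c(nc3n2[C@H]2OC[C@@H](O)[C@H]2OC3)C1=O` keeps the shared core and carries 2-ethoxyphenyl in place of 3-methoxyphenyl on an amine nitrogen as its single change.

The closest measured change also involves an ethoxy-bearing ring and is an at least 1.1-fold lower number from compound 2 to compound 3 (0.07 log units; that floor lies within the scatter) as measured. The remaining step on this part of the molecule is an at least 1.7-fold higher number from compound 1 to compound 2 (0.24 log units; that floor lies within the scatter) as measured. None of these steps leaves the ordinary spread, so no step beyond that spread is expected for compound 4 in this assay at this stage. The expectation therefore starts from compound 3 at 3340 nM and stays close to it.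

The estimated step is a 1.0-fold higher number from compound 3 to compound 4 (0.02 log units; within the scatter) and no more than that.

For compound 4 the estimated value is 3500 nM with an expected range from 1900 nM to 6500 nM in this measurement.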

Compound 4, half-maximal inhibitory concentration: 4320 nM
For compound 4 the middle estimate is 1.2-fold (0.09 log units) below the measured one; the measured number falls inside the stated range.
By their numbers in this assay, from the lowest: compounds 1, 3 and 4 (each within the scatter of the next).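

In this assay, 2-ethoxyphenyl on the amine nitrogen gives a 1.3-fold higher number from compound 3 to compound 4 (0.11 log units; within the scatter), and the wider swap from 4-(trifluoromethyl)phenyl gives a 1.9-fold higher number from compound 1 to compound 4 (0.28 log units; within the scatter). Compound 4 thus adds a further exact reading at this position, and the aromatic groups on compounds 1, 3 and 4 cannot be told apart in this assay, even though they carry different substituents: trifluoromethyl, methoxy and ethoxy. Compound 2, which also carries an ethoxy group on this ring, cannot be placed among them, and its step to compound 4 cannot be read because its value is a limit and not a number: the limit of > 4000 nM in this assay, at which 1 of the 4 values shown sits.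

What the compounds shown leave open is whether moving the ethoxy group around the ring changes the result at all, since the one comparison that would show this rests on that limit. Going by these compounds, it also remains open whether an amine or a carboxylic acid on this ring, or a longer chain in place of the ethoxy group, would move the number beyond the scatter of this assay.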